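Dichlorophenyl variant of a trimethoxyphenyl-bearing cytotoxic series

The source may hold more compounds than are shown below. What is called first, only, known or untested is meant among the compounds shown, and "the series" means these compounds.

Three compounds share one core and differ only in the aryl group on a saturated ring carbon. In a functional assay on Ehrlich cells (Mus musculus) for cytotoxicity, tested at 10 ug/mL (on this read-out lower numbers stand for a weaker effect and higher numbers for a stronger effect at the one concentration tested), compound 1 `COc1cc(N2C(N)=C(C#N)C(c3ccc(OC)c4ccccc34)C3=C2CC(C)(C)CC3=O)cc(OC)c1OC` gives 10%. Compound 2 `COc1cc(N2C(N)=C(C#N)C(c3ccc([N+](=O)[O-])cc3)C3=C2CC(C)(C)CC3=O)cc(OC)c1OC` gives 10%, and compound 3 `COc1cc(N2C(N)=C(C#N)C(c3ccc(O)cc3)C3=C2CC(C)(C)CC3=O)cc(OC)c1OC` gives 10%, so compound 3 stands level with both others at the digits shown. The steps of no change at the digits printed from compound 1 to compound 2 (within the scatter), no change at the digits printed from compound 1 to compound 3 (within the scatter) and no change at the digits printed from compound 2 to compound 3 (within the scatter) all stay within the scatter. Compound 4 `COc1cc(N2C(N)=C(C#N)C(c3ccc(Cl)cc3Cl)C3=C2CC(C)(C)CC3=O)cc(OC)c1OC` carries 2,4-dichlorophenyl in place of 4-hydroxyphenyl on a saturated ring carbon. Since each earlier exchange of this aryl group left the read-out unchanged, no step beyond the scatter is expected here; the estimated step is no change at the digits printed from compound 3 to compound 4 (within the scatter). Compound 4 is therefore expected to give about 10%, between 0% and 25%.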

Compound 4, a percentage reported as activity, at one concentration (the size of the read-out at that concentration, not a potency): 20%
The estimate for compound 4 lay 10 percentage points below the measured number; low and high end bracket the measured number.
By their numbers in this assay, from the lowest: compounds 1, 2, 3 and 4 (each within the scatter of the next).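

Against each earlier aryl group, 2,4-dichlorophenyl in this assay shows a number 10 percentage points higher from compound 3 to compound 4 (within the scatter) and a number 10 percentage points higher from compound 2 to compound 4 (within the scatter) and a number 10 percentage points higher from compound 1 to compound 4 (within the scatter) on this saturated ring carbon. Within the data shown here, the range of groups read at this position therefore now includes a phenyl ring with two chlorine atoms and no hydrogen-bond donors or acceptors, and still no step lies beyond the scatter. Nothing available bears on why the numbers fall as they do. Open, going by these compounds, is whether any aryl group here can give a step beyond the scatter. Also open, on these data alone, is how an amine, a carboxylic acid or a longer alkyl chain on this ring would read.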